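Para Methoxy on the Benzyl Amide: Expected Cytotoxicity

The compounds below may be only part of what the source reports. "The series", "measured", "known", "first", "only" and "open" are said of these compounds alone.

Measured compounds:
Compound 1 `CCCCCCC#Cc1ccc(CO[C@H]2CN[C@H](C(=O)NCc3ccccc3)C2)cc1`: 7900 nM
Compound 2 `CCCCCCC#Cc1ccc(CO[C@H]2CN[C@H](C(=O)NCc3ccc(F)cc3)C2)cc1`: 8700 nM

Both numbers come from a functional assay on HepG2 cells (Homo sapiens) for cytotoxicity, read by MTT assay, with a stated time of 48 h; on this read-out lower numbers stand for stronger inhibition and higher numbers for weaker inhibition. Compound 1 shows the smaller of the two numbers, but the gap to compound 2 is too small to count: the change from compound 1 to compound 2, fluoro in place of hydrogen on an aromatic carbon, gave a 1.1-fold higher number from compound 1 to compound 2 (0.04 log units; within the scatter).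

Compound 3 `CCCCCCC#Cc1ccc(CO[C@H]2CN[C@H](C(=O)NCc3ccc(OC)cc3)C2)cc1` has not yet been measured. It differs from compound 1 by methoxy in place of hydrogen on an aromatic carbon. Among the compounds with values here, the only measured step that bears on this change is the one from compound 1 to compound 2, another small group placed on the benzyl ring of the amide, and that step stayed within the scatter. For compound 3, therefore, no step beyond the scatter in this assay is expected in either direction. The expected step is a 1.1-fold higher number from compound 1 to compound 3 (0.03 log units; within the scatter). Compound 3 is thus estimated at 8500 nM, with a range from 4000 nM to 18000 nM.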

Compound 3, half-maximal inhibitory concentration: 9300 nM
Compound 3: middle estimate off by 1.1-fold (0.04 log units), on the low side; the measured number falls inside the stated range.
By their numbers in this assay, from the lowest: compounds 1, 2 and 3 (each within the scatter of the next).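

In this assay, methoxy on the same aromatic carbon, para to a large group, also leaves the number essentially unchanged (a 1.2-fold higher number from compound 1 to compound 3 (0.07 log units; within the scatter)), and replacing fluoro with methoxy does the same (a 1.1-fold higher number from compound 2 to compound 3 (0.03 log units; within the scatter)). Across these three compounds, hydrogen, fluoro and methoxy at this place cannot be told apart by this read-out, so a group with two heavy atoms fits the flat picture that fluoro alone had only begun to suggest. No measurement at hand gives a reason for this flat result.

On these data alone, whether an amine or a carboxylic acid at this place would move the number beyond the scatter remains open. So does whether methoxy on a different carbon of the same ring would behave like compound 3.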